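This account rests on a few compounds, and the source may have more. Where it says the series, first, only, none or still open, it means among the compounds named here.

Working notes on a small series sharing one core, tested in a functional assay on the whole organism (strain CD-1) with Mus musculus as the target, with a stated time of 0.5 h; on this read-out lower numbers stand for an effect already at smaller amounts and higher numbers for an effect only at larger amounts of compound. Compound 1 `CC1(c2ccccc2)CC(=O)N(CC(=O)N2CCN(c3cccc(Cl)c3Cl)CC2)C1=O` gives 300 mg/kg. Within the data shown here, compound 2 `CC1(c2ccccc2)CC(=O)N(CC(=O)N2CCN(c3ccc(F)cc3)CC2)C1=O` is reported only as "not active" (no number reported), so compound 2 stands without a single number in this assay, and no step from compound 2 to compound 1 can be sized. Compound 3 `CC1(c2ccccc2)CC(=O)N(CC(=O)N2CCN(c3cccc(C(F)(F)F)c3)CC2)C1=O` is not yet measured; it carries 3-(trifluoromethyl)phenyl in place of 4-fluorophenyl on an amine nitrogen in a ring. With compound 2 lacking a number, no step size can be computed for compound 3; by comparison with compound 1 at 300 mg/kg, compound 3 is expected to show some effect at a dose estimated near 300 mg/kg, within a range from 100 mg/kg to 1000 mg/kg.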

Compound 3, minimum effective dose: "not active" (no number reported)
Compound 3 has no reported number here, so the estimate cannot be set against anything.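

Among these compounds, compound 2 and compound 3 are both reported only as not active, without a number, so no step between them can be read. The compounds shown leave open how far 4-fluorophenyl and 3-(trifluoromethyl)phenyl differ in effect, and no measured evidence bears on this result.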